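Swapping a chloro for a bromo on a shared core

A few compounds are considered here, and "the series" means these few. Any claim that something is new, unique, unknown or untested is made for them only; others in the source may bear on it.

Of the compounds shown here, two sharing one core have been measured in a functional assay on the whole organism (strain Wistar) with Rattus norvegicus as the target, with a stated time of 15 days, at a dose of 3 mg/kg by the oral route; a lower number here means a weaker effect, a higher number a stronger effect of the compound at the dose given. Compound 1 `O=C1NC(=O)/C(=C/c2ccc(OCCSc3nnc(-c4ccccc4[N+](=O)[O-])[nH]3)cc2)S1` gives 19.8%, and compound 2 `O=C1NC(=O)/C(=C/c2ccc(OCCSc3nnc(-c4ccc(Cl)cc4)[nH]3)cc2)S1` gives 23.9%. Going by the values given here, compound 2 holds the higher of the two numbers, but the only step connecting them, a number 4.1 percentage points higher from compound 1 to compound 2 (within the scatter), is within the scatter, so the two values cannot be told apart with confidence.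

Compound 3 `O=C1NC(=O)/C(=C/c2ccc(OCCSc3nnc(-c4ccc(Br)cc4)[nH]3)cc2)S1` is compound 2 with one change: bromo in place of chloro on an aromatic carbon. Among the compounds with values here, no measured pair here involves a bromo group, and the one step that exists, a number 4.1 percentage points higher from compound 1 to compound 2 (within the scatter), concerns a different change at a different point and is itself within the scatter. The data therefore give no direct guide to the chloro-to-bromo exchange, and the closest structural analogy argues for a modest effect at most.

For compound 3 in this assay the expected number is 24%, with a range from 12% to 36%. This estimate implies a step of a number 0.1 percentage points higher from compound 2 to compound 3 (within the scatter), which is expected to stay within the scatter.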

Compound 3, a percentage reported as activity, at one dose (the size of the read-out at that dose, not a potency): 28.4%
Beside the measured number, compound 3's estimate is 4.4 percentage points below it, and the stated range covers the measured number.
By their numbers in this assay, from the lowest: compounds 1, 2 and 3 (each within the scatter of the next).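

In this assay, going by these compounds alone, the exchange of chloro for bromo on an aromatic carbon, para to a large group, gives a number 4.5 percentage points higher from compound 2 to compound 3 (within the scatter) and so offers the first direct look at one halogen replacing another at this position: at this single dose, the two halogens cannot be told apart. The wider comparison of 4-bromophenyl with 2-nitrophenyl gives a number 8.6 percentage points higher from compound 1 to compound 3 (within the scatter) and stays within the usual variation as well, so even this larger change of substituent and its position produces no clear separation between the two compounds. No independent measurement available here bears on this result or accounts for these numbers.

The compounds shown leave open whether an amine or a carboxylic acid on this same aromatic ring would shift the read-out clearly beyond the usual variation, or whether such groups would also leave it unresolved. They also leave open how a longer chain in place of the one in the shared core would behave, and whether differences would emerge at other doses.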